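Bromo to dimethylamino: a first look at compound 3

This account rests on a few compounds, and the source may have more. Where it says the series, first, only, none or still open, it means among the compounds named here.

Measured so far in a functional assay on MCF7 cells (Homo sapiens) for antiproliferative activity, read by MTT assay, with a stated time of 48 h; on this read-out higher numbers stand for weaker inhibition and lower numbers for stronger inhibition:
compound 1 `COc1ccc(C(=O)c2ccc3c(c2)C=CC(C)(C)O3)c(NC(=O)CBr)c1` gives 2880 nM here
compound 2 `COc1ccc(C(=O)c2ccc(OC)c3c2OC(C)(C)C=C3)c(NC(=O)CN(C)C)c1` gives 2680 nM here

Among the measured compounds shown here, compound 1 stands within the scatter of compound 2, the only other measured compound, so these two numbers set no order. Compound 3 `COc1ccc(C(=O)c2ccc3c(c2)C=CC(C)(C)O3)c(NC(=O)CN(C)C)c1` keeps the core of compound 1 and changes one group (dimethylamino in place of bromo on a saturated chain carbon bound to a carbonyl carbon) on the chain, with dimethylamino in place of bromo on a saturated chain carbon bound to a carbonyl carbon. For the measured compounds named here, no measured pair isolates this change. Compound 2 also carries dimethylamino on the chain and gives 2680 nM in this assay despite differences in its core, so no step beyond the scatter is expected, and no direction is favoured. The expected outcome is a 1.2-fold lower number from compound 1 to compound 3 (0.06 log units; within the scatter) in this comparison. For compound 3 the estimated value is 2500 nM with an expected range from 700 nM to 9000 nM in this assay for now.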

Compound 3, half-maximal inhibitory concentration: 3560 nM
For compound 3 the middle estimate is 1.4-fold (0.15 log units) below the measured one; measured number inside the range.
By their numbers in this assay, from the lowest: compounds 2, 1 and 3 (each within the scatter of the next).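

In this assay this pair, the first to isolate the change, gives a 1.2-fold higher number from compound 1 to compound 3 (0.09 log units; within the scatter) and thus shows that on the core of compound 1 dimethylamino in place of bromo on a saturated chain carbon bound to a carbonyl carbon leaves the read-out within the scatter. At this place the assay does not tell bromo, with 1 heavy atom, from dimethylamino, with 3 heavy atoms. Nothing at hand ties this outcome to any property of either group.

As far as these compounds go, whether a primary amine, a carboxylic acid or a longer chain at this place would give a step beyond the scatter remains open. From the compounds shown here alone, it is also open whether the same exchange reads alike on the core of compound 2.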